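The compounds below may be only part of what the source reports. "The series", "measured", "known", "first", "only" and "open" are said of these compounds alone.

Measured so far in the series:
compound 1 `CCCCCCCCCCn1cc(-c2nc3ccccc3cc2CC)nn1`: 12.7 ug/mL
compound 3 `CCCCCCCCCCn1cc(-c2nc3ccccc3cc2CCCCC)nn1`: 18.2 ug/mL
compound 2 `CCCCCc1cc2ccccc2nc1-c1cn(CCC(F)(F)C(F)(F)C(F)(F)C(F)(F)C(F)(F)C(F)(F)C(F)(F)C(F)(F)F)nn1`: a limit only, > 100 ug/mL

In a functional assay on U-937 cells (Homo sapiens) for cytotoxicity, read by MTT assay, with a stated time of 24 h (on this read-out higher numbers stand for weaker inhibition and lower numbers for stronger inhibition), compound 3 gives 18.2 ug/mL and compound 1 gives 12.7 ug/mL. For compound 2 this assay reports only a limit, > 100 ug/mL, and no number. Going by the values given here, the one measured step within a shared core is a 1.4-fold lower number from compound 3 to compound 1 (0.16 log units; within the scatter), made by hydrogen in place of propyl on a saturated chain carbon, two bonds along the chain from an aromatic carbon. Among the compounds with values here, how the core of compound 2 differs from the core of compound 3 is not broken down here; the two values show only that compound 2 sits at the limit of > 100 ug/mL in this assay, at which 1 of the 3 values shown sits, while compound 3 returns a number.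

Compound 4 `CCc1cc2ccccc2nc1-c1cn(CCC(F)(F)C(F)(F)C(F)(F)C(F)(F)C(F)(F)C(F)(F)C(F)(F)C(F)(F)F)nn1` is not yet measured. It differs from compound 2 by hydrogen in place of propyl on a saturated chain carbon, two bonds along the chain from an aromatic carbon, the same change, at the same place, as from compound 3 to compound 1. Since that change moved the number within the scatter, the step that the limit leaves unreadable from compound 2 to compound 4 is expected to be of the same small size. Compound 4 is therefore estimated at 120 ug/mL, between 40 ug/mL and 400 ug/mL, and this assay is expected most often to report only a limit again for compound 4, because compound 2 gives > 100 ug/mL.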

Compound 4, half-maximal inhibitory concentration: 55.9 ug/mL
Compound 4: the middle estimate sits 2.1-fold (0.33 log units) above what was measured; the range from low to high includes it.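

In this assay, exchanging pentyl for ethyl on the second core gives an at least 1.7-fold lower number from compound 2 to compound 4 (0.25 log units; that floor lies within the scatter). This shows that the change can be followed on two cores, and neither printed reading goes beyond the scatter, but the second reading is only a floor, so it does not show that the size of the step carries over from one core to the other: the same change on two cores in this assay, a 1.4-fold lower number (0.16 log units; within the scatter) from compound 3 to compound 1 and an at least 1.7-fold lower number (0.25 log units; that floor lies within the scatter) from compound 2 to compound 4; the limit leaves it open whether they differ Compound 2 gives a limit and not a number, so the true size of its step stays unknown: the limit of > 100 ug/mL in this assay, at which 1 of the 4 values shown sits.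

The compounds shown leave open how the number moves when an amine, a carboxylic acid or a chain longer than pentyl stands in place of ethyl or pentyl on either core. They also leave open whether the step from pentyl to ethyl is larger on the core of compound 2 than on the core of compound 3, a comparison that would need a number for compound 2 in place of its limit.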